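A few compounds are considered here, and "the series" means these few. Any claim that something is new, unique, unknown or untested is made for them only; others in the source may bear on it.

Measured compounds:
- compound 1, `CC(C)c1ccc(CSc2ncnc3c2ncn3[C@@H]2O[C@H](CO)[C@@H](O)[C@H]2O)cc1`: 4790 nM
- compound 2, `OC[C@H]1O[C@@H](n2cnc3c(SCCCc4ccccc4)ncnc32)[C@H](O)[C@@H]1O`: 1350 nM
- compound 3, `CCC(C)Sc1nc(N)nc2c1ncn2[C@@H]1O[C@H](CO)[C@@H](O)[C@H]1O`: 63100 nM

In an assay on isolated protein for binding affinity to Equilibrative nucleoside transporter 1 (Homo sapiens) (on this read-out lower numbers stand for stronger inhibition and higher numbers for weaker inhibition), compound 3 gives the highest number of the three, and its gap to compound 1 and to compound 2 lies beyond the scatter, so it is the weakest of the measured compounds. Compound 4, `Nc1nc(SCc2ccccn2)c2ncn([C@@H]3O[C@H](CO)[C@@H](O)[C@H]3O)c2n1`, differs from compound 3 in one place: (pyridin-2-yl)methyl in place of sec-butyl on a sulfur. For the measured compounds named here, no measured step changes exactly this. Going by the values given here, the one measured step, a 3.5-fold lower number from compound 1 to compound 2 (0.55 log units; beyond the scatter), shows that reshaping the group on the sulfur can move the number by a modest amount. Beyond that, compound 1 and compound 2, which both carry a group with an aromatic ring on the sulfur, give far lower numbers than compound 3, which carries sec-butyl there, although the two cores also differ. On that basis a lower number is expected for compound 4, by a 6.3-fold lower number from compound 3 to compound 4 (0.80 log units; beyond the scatter), with wide uncertainty since the cores are not the same. The estimate for compound 4 in this assay is 10000 nM, within 2500 nM to 40000 nM.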

Compound 4, half-maximal inhibitory concentration: 34700 nM
The estimate for compound 4 lay 3.5-fold (0.54 log units) below the measured number, within the range that was stated.
By their numbers in this assay, from the lowest: compound 2; then compound 1; then compounds 4 and 3 (each within the scatter of the next).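

In this assay, replacing sec-butyl on the sulfur with (pyridin-2-yl)methyl gives a 1.8-fold lower number from compound 3 to compound 4 (0.26 log units; within the scatter). The earlier step, measured on a different core, showed that changing the group on the sulfur can move the number, whereas on this core a swap that adds an aromatic ring and a hydrogen-bond acceptor produces no change that can be told from scatter. No measurement shown explains this result.

Going by these compounds, it remains open whether a plain benzyl group, with a carbon in place of the ring nitrogen, or a longer chain ending in a phenyl ring would behave the same way on this core. It is also unknown how (pyridin-2-yl)methyl on the sulfur would read on the core of compound 1.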